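The source may hold more compounds than are shown below. What is called first, only, known or untested is meant among the compounds shown, and "the series" means these compounds.

Three measured members of the series share one core. Compound 1 `NC(=O)c1c(NC(=O)c2ccccc2Br)sc2c1CCN(C(=S)Nc1ccccc1Cl)C2` gives 14600 nM in a functional assay on HL-60 cells (Homo sapiens) for antiproliferative activity, with a stated time of 24 h; a higher number here means a weaker inhibitor, a lower number a stronger inhibitor; compound 2 `NC(=O)c1c(NC(=O)c2ccccc2I)sc2c1CCN(C(=S)Nc1ccccc1Cl)C2` gives 8560 nM; compound 3 `Cc1ccccc1C(=O)Nc1sc2c(c1C(N)=O)CCN(C(=S)Nc1ccccc1Cl)C2` gives 20900 nM. Compound 1 thus sits second highest of the three numbers, with compound 3 nearest and compound 2 furthest, both differences within the scatter.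

Compound 4 `Cc1ccccc1NC(=S)N1CCc2c(sc(NC(=O)c3ccccc3Br)c2C(N)=O)C1` differs from compound 1 in one place: methyl in place of chloro on an aromatic carbon. For the measured compounds named here, no measured step touches this part of the shared core; all three measured steps exchange a group elsewhere on the molecule: a 1.7-fold lower number from compound 1 to compound 2 (0.23 log units; within the scatter), a 1.4-fold higher number from compound 1 to compound 3 (0.16 log units; within the scatter) and a 2.4-fold higher number from compound 2 to compound 3 (0.39 log units; beyond the scatter). Going by the values given here, the closest parallel, a methyl entering for a halogen, is a 1.4-fold higher number from compound 1 to compound 3 (0.16 log units; within the scatter), which lies within the scatter, and the one modest step among the three, a 2.4-fold higher number from compound 2 to compound 3 (0.39 log units; beyond the scatter), concerns an iodo that compound 4 does not carry. Hence no step beyond the scatter is expected for compound 4 in this assay, that is a 1.0-fold higher number from compound 1 to compound 4 (0.01 log units; within the scatter). Compound 4 is estimated at 15000 nM, in the range 7000 nM to 32000 nM.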

Compound 4, half-maximal inhibitory concentration: > 50000 nM
Compound 4: a limit, no number (the forecaster's own chance of this, stated with the estimate: 10%); at least 3.3-fold (0.52 log units) between middle value and limit.
By their numbers in this assay, from the lowest: compounds 2, 1 and 3 (each within the scatter of the next, the first and the last beyond it). At a limit, above all of these: compound 4.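

The aromatic carbon ortho to a large group, in the (2-chlorophenyl)amino part, proves sensitive in this assay: methyl in place of chloro here gives an at least 3.4-fold higher number from compound 1 to compound 4 (0.53 log units; beyond the scatter). Compound 4 stands at a limit and not a number, > 50000 nM, so the full size of this step stays unknown: the limit of > 50000 nM in this assay, at which 1 of the 4 values shown sits.

A methyl entering for a halogen elsewhere on the molecule gives a 1.4-fold higher number from compound 1 to compound 3 (0.16 log units; within the scatter), so this exchange does not read the same at both places.

On these data alone, whether a fluoro, a methoxy or an amine at this position would keep the level of compound 1 remains open. As far as these compounds go, with one change here and a limit as its result, no trend across groups can be drawn, and whether the same exchange would act alike on the iodo partner, compound 2, is also open.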